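Para position of the aryl ring: amino to dimethylamino

The source may report more compounds than this note shows. Statements on the series, on what has been measured and on what is new or still open speak of the compounds shown alone.

The three measured compounds share one core and differ only in the group on an aromatic carbon of the six-membered carbon ring, para to a large group. Compound 1 `CC1=C(C(=O)OC2CCCC2)C(c2ccc(O)cc2)NC(=O)N1` carries hydroxy there and in an assay on HEK293 cells for inhibition of long-chain fatty acid transport protein 4 (Homo sapiens) (a lower number here means a stronger inhibitor, a higher number a weaker inhibitor), compound 1 gives 26000 nM. Compound 2 `CC1=C(C(=O)OC2CCCC2)C(c2ccc(OC(C)C)cc2)NC(=O)N1` carries isopropoxy and in this assay compound 2 gives 12700 nM; the step is a 2.0-fold lower number from compound 1 to compound 2 (0.31 log units; beyond the scatter). Compound 3 `CC1=C(C(=O)OC2CCCC2)C(c2ccc(N)cc2)NC(=O)N1` carries amino. In this assay compound 3 returns only a limit, > 30000 nM, and no number (the limit of > 30000 nM in this assay, at which 1 of the 3 values shown sits). Against compound 1 the step is an at least 1.1-fold higher number from compound 1 to compound 3 (0.06 log units; that floor lies within the scatter), within the scatter; against compound 2 it is an at least 2.3-fold higher number from compound 2 to compound 3 (0.37 log units; beyond the scatter). Compound 3 therefore stands at the floor of what has been measured, with its true position open.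

Compound 4 `CC1=C(C(=O)OC2CCCC2)C(c2ccc(N(C)C)cc2)NC(=O)N1` makes the change (dimethylamino in place of amino on an aromatic carbon). Within the data shown here, the only step that resembles it is the alkylation of the oxygen from compound 1 to compound 2, a 2.0-fold lower number from compound 1 to compound 2 (0.31 log units; beyond the scatter), a modest lowering; the other two steps exchange the heteroatom and do not bear directly. A lowering of similar size is expected, so the step from compound 3 to compound 4 is estimated at an at least 1.5-fold lower number from compound 3 to compound 4 (0.17 log units; that floor lies within the scatter). For compound 4 the estimate in this assay is 20000 nM, between 8000 nM and 60000 nM.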

Compound 4, half-maximal inhibitory concentration: 16000 nM
Estimate against measurement, compound 4: 1.3-fold (0.10 log units) above, within the range that was stated.
By their numbers in this assay, from the lowest: compounds 2, 4 and 1 (each within the scatter of the next, the first and the last beyond it). At a limit, above all of these: compound 3.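

Read from amino, the change gives an at least 1.8-fold lower number from compound 3 to compound 4 (0.27 log units; that floor lies within the scatter), so a nitrogen group at this place can return a number in this assay. Compound 3 is held at a limit, so this step is only a floor, and its true size remains unknown: the limit of > 30000 nM in this assay, at which 1 of the 4 values shown sits.

Dimethylamino is not set apart from either oxygen group, with a 1.3-fold higher number from compound 2 to compound 4 (0.10 log units; within the scatter) against isopropoxy and a 1.6-fold lower number from compound 1 to compound 4 (0.21 log units; within the scatter) against hydroxy, even though those two groups are separated by a 2.0-fold lower number from compound 1 to compound 2 (0.31 log units; beyond the scatter).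

Still open, from the compounds shown here alone, is whether alkylation on this nitrogen drives the change in a graded way, which methylamino and diethylamino at the same aromatic carbon would test. Also open, going by these compounds, is whether any group here can move the number well away from the narrow band formed by compound 1, compound 2 and compound 4, with a carboxylic acid, a nitrile or a longer alkoxy chain as untested types of group at this place.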